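The source may report more compounds than this note shows. Statements on the series, on what has been measured and on what is new or still open speak of the compounds shown alone.

Compound 1 `CC(C)(C)c1ccc(C(=O)NCc2ccc(C(N)=O)cc2)cc1` stands at the higher of the two numbers recorded so far in an assay on HeLa cells with Bile acid receptor (Homo sapiens) as the target, read by a luciferase reporter, with a stated time of 24 h (a higher number here means that more compound is needed for the effect, a lower number that less compound is needed), giving 3800 nM. Compound 2 `CC(C)(C)c1ccc(C(=O)NCc2ccc(C(=O)O)cc2F)cc1` gives 7.8 nM in the same assay, a far lower number. Compound 3 `COc1ccc(CNC(=O)c2ccc(C(C)(C)C)cc2)cc1` differs from compound 1 in one place: methoxy in place of carbamoyl on an aromatic carbon. Going by the values given here, no measured pair shows a change of this kind, so the step of a 3.2-fold higher number from compound 1 to compound 3 (0.50 log units; beyond the scatter) is an expectation only; a shift toward a higher number, beyond the scatter, is expected. Compound 3 is therefore estimated at 12000 nM, with a likely range from 2500 nM to 60000 nM.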

Compound 3, half-maximal effective concentration: 150 nM
Compound 3: the middle estimate sits 80-fold (1.90 log units) above what was measured, and the stated range ends above it.
By their numbers in this assay, from the lowest: compound 2; then compound 3; then compound 1.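

On this aromatic carbon, para to a large group, methoxy in place of carbamoyl gives a 25-fold lower number from compound 1 to compound 3 (1.40 log units; beyond the scatter) in this assay and so shows that this position responds strongly to the group it carries. The group that leaves has a hydrogen-bond donor and the one that enters has none, but this single pair cannot link that difference to the step, and nothing at hand explains it. From the compounds shown here alone, it remains open whether methoxy itself matters or only the loss of carbamoyl, and how a nitrile, an amine or a longer ethoxy chain would behave on this carbon.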